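This account rests on a few compounds, and the source may have more. Where it says the series, first, only, none or still open, it means among the compounds named here.

Of the compounds shown here, three on one shared core have been measured in a functional assay on HeLa cells (Homo sapiens) for antiproliferative activity, read by CCK-8 assay, with a stated time of 72 h; a lower number here means a stronger inhibitor, a higher number a weaker inhibitor. Compound 1 `Cc1cc(Nc2cc(N3CCN(C)CC3)nc(Nc3ccc(S(N)(=O)=O)cc3)n2)n[nH]1` gives 3060 nM, compound 3 `Cc1cc(Nc2cc(N3CCN(C)CC3)nc(Nc3cccc([N+](=O)[O-])c3)n2)n[nH]1` gives 1110 nM, and compound 2 `Cc1cc(Nc2cc(N3CCN(C)CC3)nc(Nc3ccc([N+](=O)[O-])cc3)n2)n[nH]1` gives 331 nM, the lowest of the three numbers. Compound 4 `Cc1cc(Nc2cc(N3CCN(C)CC3)nc(Nc3cccc(Cl)c3)n2)n[nH]1` has not yet been measured. It carries 3-chlorophenyl in place of 4-nitrophenyl on a nitrogen on an aromatic ring.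

The closest evidence is a 3.4-fold higher number from compound 2 to compound 3 (0.53 log units; beyond the scatter), where 3-nitrophenyl replaces 4-nitrophenyl at that same place. The other two steps, a 9.2-fold lower number from compound 1 to compound 2 (0.97 log units; beyond the scatter) and a 2.8-fold lower number from compound 1 to compound 3 (0.44 log units; beyond the scatter), show that the group on this nitrogen can shift the number in either direction. Among the measured compounds shown here, no measured compound carries 3-chlorophenyl, so the size of this change remains uncertain. A modest move to a higher number is therefore expected in this assay, similar in size to the step from the 4-nitrophenyl to the 3-nitrophenyl compound. The expected change is a 2.4-fold higher number from compound 2 to compound 4 (0.38 log units; beyond the scatter). For compound 4 the estimate is 800 nM, with an expected range from 250 nM to 2500 nM.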

Compound 4, half-maximal inhibitory concentration: 425 nM
For compound 4 the middle estimate is 1.9-fold (0.27 log units) above the measured one; the range from low to high includes it.
By their numbers in this assay, from the lowest: compounds 2 and 4 (each within the scatter of the next); then compound 3; then compound 1.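

In this assay, the step to 3-chlorophenyl on this nitrogen reads a 1.3-fold higher number from compound 2 to compound 4 (0.11 log units; within the scatter), so a group other than 4-nitrophenyl can stand here and stay within the scatter of compound 2. With the ring otherwise unchanged, chloro in place of nitro gives a 2.6-fold lower number from compound 3 to compound 4 (0.42 log units; beyond the scatter), which shows that the number of compound 3 does not hold for every 3-substituted phenyl at this place, while the step against the sulfamoyl compound, a 7.2-fold lower number from compound 1 to compound 4 (0.86 log units; beyond the scatter), leaves compound 1 apart from the chloro compound as well as the nitro compounds. No measurement at hand gives a reason for any of these steps.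

Among the compounds shown here, how 4-chlorophenyl would compare with 3-chlorophenyl on this nitrogen stays open, leaving the 4-nitrophenyl and 3-nitrophenyl pair as the only such comparison. Also open, from the compounds shown here alone, is how a phenyl ring carrying an amine or a carboxylic acid would read at this place.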